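Chain Extension at the Ester Arm of Compound 2

The compounds below may be only part of what the source reports. "The series", "measured", "known", "first", "only" and "open" are said of these compounds alone.

Compound 1 `CC1(C)CCC[C@]2(C)[C@@H](C=O)C(C=O)=CC[C@@H]12`: > 100000 nM
Compound 2 `CCOC(=O)/C=C/C1=CC[C@H]2C(C)(C)CCC[C@]2(C)[C@H]1C=O`: 37000 nM
Compound 3 `CC1(C)CCC[C@]2(C)[C@@H](C=O)C(/C=C/C(=O)OCc3ccccc3)=CC[C@@H]12`: 39000 nM

Of the compounds shown here, three sharing one core have been measured in a functional assay on U-373MG ATCC cells (Homo sapiens) for inhibition, read by MTT assay, with a stated time of 72 h; on this read-out higher numbers stand for weaker inhibition of growth and lower numbers for stronger inhibition of growth. For compound 1 the assay reports only a limit, > 100000 nM, and no number. Compound 2 gives 37000 nM, the lowest of the two numbers shown; compound 3 gives 39000 nM, which sits within the scatter of compound 2. The step of an at least 2.7-fold lower number from compound 1 to compound 2 (0.43 log units; beyond the scatter) is the only one beyond the scatter, while a 1.1-fold higher number from compound 2 to compound 3 (0.02 log units; within the scatter) shows that the alkyl part of the ester can be changed without moving the number.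

Compound 4 `COC(=O)/C=C/C=C/C1=CC[C@H]2C(C)(C)CCC[C@]2(C)[C@H]1C=O` is not yet measured. It differs from compound 2 by 2-(methoxycarbonyl)ethenyl in place of ethoxycarbonyl on a double-bonded chain carbon bound to a double-bonded chain carbon. The change of ester alkyl in the step from compound 2 to compound 3 bears on the methyl-for-ethyl part and was flat; nothing measured bears on the added ethenyl. The expected step is therefore a 1.1-fold lower number from compound 2 to compound 4 (0.02 log units; within the scatter), none beyond the scatter. Compound 4 is estimated at 35000 nM, between 15000 nM and 85000 nM.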

Compound 4, concentration for 50% growth inhibition: 27000 nM
Compound 4: the middle estimate sits 1.3-fold (0.11 log units) above what was measured; the measured number falls inside the stated range.
By their numbers in this assay, from the lowest: compounds 4, 2 and 3 (each within the scatter of the next). At a limit, above all of these: compound 1.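

The earlier compounds shown here changed only the alkyl part of the ester, whereas here the arm itself grows, with 2-(methoxycarbonyl)ethenyl in place of ethoxycarbonyl on a double-bonded chain carbon bound to a double-bonded chain carbon. In this assay this gives a 1.4-fold lower number from compound 2 to compound 4 (0.14 log units; within the scatter) and so shows that the position takes the longer arm, with its second double bond outside aromatic rings, while compound 4 stays within the scatter of compound 2. Nothing measured here gives a reason for this flat step.

The compounds shown leave open whether a still longer chain carrying a further ethenyl would hold the same level, and whether a carboxylic acid or an amide in place of the ester would do so. They also leave open whether any change on this arm can move the number beyond the scatter of compound 2.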